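The compounds below may be only part of what the source reports. "The series", "measured", "known", "first", "only" and "open" are said of these compounds alone.

In an ADME assay on microsomes from liver (Homo sapiens) for metabolic stability, tested at 2.5 uM (on this read-out higher numbers stand for fast clearance and lower numbers for slow clearance), compound 3 `COc1ccc(-c2c(S(=O)(=O)c3ccc(OC)cc3)cnc3cc(F)ccc23)cc1` gives 1.18 mL/min, the second highest of the three numbers. Compound 2 `COc1ccc(S(=O)(=O)c2cnc3cc(F)ccc3c2-c2ccc(Cl)cc2)cc1` gives 1.28 mL/min, within the scatter of compound 3. Compound 1 `O=S(=O)(c1ccc(F)c(Cl)c1)c1cnc2c(F)cccc2c1-c1cccc(Cl)c1` gives 0.18 mL/min, a much lower number than compound 3. Compound 4 `COc1ccc(-c2c(S(=O)(=O)c3ccc(F)c(F)c3)cnc3cc(F)ccc23)cc1` is not yet measured in this assay; it differs from compound 3 by 3,4-difluorophenyl in place of 4-methoxyphenyl on a sulfonyl sulfur. For the measured compounds named here, the only measured step, a 1.1-fold lower number from compound 2 to compound 3 (0.04 log units; within the scatter), exchanged methoxy for chloro on an aromatic carbon and stayed within the scatter. Compound 1 carries a halogen-bearing ring on its sulfonyl sulfur and stands well below compound 3, yet it also differs elsewhere. A modest fall in this assay, a 1.7-fold lower number from compound 3 to compound 4 (0.23 log units; within the scatter), is therefore expected, with wide uncertainty. Compound 4 is estimated at 0.7 mL/min, between 0.3 mL/min and 1.6 mL/min.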

Compound 4, intrinsic clearance in a liver preparation (reported as CLH), per the amount of preparation that the assay uses: 1.1 mL/min
The estimate for compound 4 lay 1.6-fold (0.20 log units) below the measured number; measured number inside the range.
By their numbers in this assay, from the lowest: compound 1; then compounds 4, 3 and 2 (each within the scatter of the next).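

At the sulfonyl sulfur, 3,4-difluorophenyl in place of 4-methoxyphenyl gives no change beyond the scatter in this assay (a 1.1-fold lower number from compound 3 to compound 4 (0.03 log units; within the scatter)). For the compounds shown here, this is the first step read at this position, and in this pair the read-out does not separate the two aromatic rings. No measurement shown accounts for this result.

On these data alone, whether an amine or a carboxylic acid on this ring would shift the number remains open. So does which of the several differences in compound 1 goes with its much lower number.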